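Carbonyl substituent changes and metabolic stability in the series

The compounds below may be only part of what the source reports. "The series", "measured", "known", "first", "only" and "open" are said of these compounds alone.

Of the compounds shown here, two have been measured in an ADME assay on liver (Homo sapiens) for metabolic stability, read by LC-MS, using S9 fraction and NADPH, with a stated time of 45 min, tested at 1 uM; a lower number here means that the compound disappears faster, a higher number that the compound lasts longer. Compound 1 `Cc1cc(/C=C/C#N)cc(C)c1Oc1cc(Nc2ccc(C#N)cc2)c(N)cc1C(=O)OCCC#N` gives 0.2 h. Compound 2 `Cc1cc(/C=C/C#N)cc(C)c1Oc1cc(Nc2ccc(C#N)cc2)c(N)cc1C(=O)NN` gives 0.65 h, the higher of the two numbers; the step between them is a 3.3-fold higher number from compound 1 to compound 2 (0.51 log units; beyond the scatter). Within the data shown here, compound 2 thus stands at the top of what has been measured, with compound 1 as its only neighbour.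

Compound 3 `CNC(=O)c1cc(N)c(Nc2ccc(C#N)cc2)cc1Oc1c(C)cc(/C=C/C#N)cc1C` has not yet been measured. It differs from compound 2 by methyl in place of amino on an amide-type nitrogen. Among the measured compounds shown here, the one measured step, from compound 1 to compound 2, alters what sits on the carbonyl carbon, not what sits on the amide-type nitrogen, so it does not speak directly to this change; no closer precedent exists among the measured compounds. A step of a 1.2-fold lower number from compound 2 to compound 3 (0.07 log units; within the scatter) is therefore expected, kept within the scatter for want of any guiding pair. Compound 3 is estimated at 0.55 h, between 0.22 h and 1.4 h.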

Compound 3, half-life in the liver assay: 1.6 h
For compound 3 the middle estimate is 2.9-fold (0.46 log units) below the measured one, outside the stated range (above it).
By their numbers in the liver assay, from the lowest: compound 1; then compound 2; then compound 3.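

In the liver assay, the group on the amide-type nitrogen proves to matter as well as the group on the carbonyl carbon: methyl in place of amino gives a 2.5-fold higher number from compound 2 to compound 3 (0.39 log units; beyond the scatter), and exchanging 2-cyanoethoxy on a carbonyl carbon for methylamino gives an 8.0-fold higher number from compound 1 to compound 3 (0.90 log units; beyond the scatter). In a physicochemical assay for lipophilicity, read by HPLC, measured as octanol-water partition, with a stated time of 24 h, at pH 7.4 (a higher number here means a more lipophilic compound, a lower number a more polar compound), compound 2 gives 2.31 and compound 3 gives 2.65. The longer-lasting compound of this pair is therefore also the more lipophilic one, so here the methyl change raises lipophilicity without a loss of half-life: the measured partition coefficient of compound 2, 2.31, and of compound 3, 2.65, a number 0.34 log units higher (beyond the scatter)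

Still open, on these data alone, is whether a longer chain such as ethyl on the amide-type nitrogen, or a dimethylamino group on the carbonyl carbon, would last longer still in the liver assay. A single pair also cannot tell whether partition coefficient and half-life move together across the series.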